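The compounds below may be only part of what the source reports. "The series", "measured", "known", "first", "only" and "open" are said of these compounds alone.

Of the compounds shown here, three sharing one core have been tested in a functional assay on HT-29 cells (Homo sapiens) for cytotoxicity, read by MTT assay, with a stated time of 72 h; on this read-out higher numbers stand for weaker inhibition and lower numbers for stronger inhibition. Compound 1 `CCOC(=O)c1sc2ccccc2c1Nc1cc(OC)c(OC)c(OC)c1` gives 1610 nM. Compound 2 `COC(=O)c1sc2cc(C)ccc2c1Nc1cc(OC)c(OC)c(OC)c1` gives 1.9 nM, the lowest of the three numbers. Compound 3 `CCOC(=O)c1sc2cccc(C)c2c1Nc1cc(OC)c(OC)c(OC)c1` gives 3610 nM. How the core of compound 2 differs from that of compound 3 is not broken down here.

Between compound 3 and compound 1 the change is hydrogen in place of methyl on an aromatic carbon, and this gave a 2.2-fold lower number from compound 3 to compound 1 (0.35 log units; beyond the scatter). Compound 4 `COC(=O)c1sc2ccccc2c1Nc1cc(OC)c(OC)c(OC)c1`, not yet measured, is related to compound 2 by hydrogen in place of methyl on an aromatic carbon. This is the same kind of change, but the place differs: in compound 3 the methyl sits ortho to a fused ring and meta to a fused ring, whereas in compound 2 it sits meta to a fused ring and para to a fused ring.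

Because the first step was only a 2.2-fold lower number from compound 3 to compound 1 (0.35 log units; beyond the scatter), compound 4 is expected to stay close to compound 2, with a 4.2-fold higher number from compound 2 to compound 4 (0.62 log units; beyond the scatter) as the expected step. Compound 4 is estimated at 8 nM in this assay, between 1.5 nM and 50 nM.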

Compound 4, half-maximal inhibitory concentration: 299 nM
Estimate against measurement, compound 4: 37-fold (1.57 log units) below; measured number above the stated range.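

In this assay, swapping a methyl on an aromatic carbon for hydrogen did not carry over from one core to the other, as the two steps set side by side show: the same change on two cores in this assay, a 2.2-fold lower number (0.35 log units; beyond the scatter) from compound 3 to compound 1 and a 160-fold higher number (2.20 log units; beyond the scatter) from compound 2 to compound 4, 350-fold (2.55 log units) apart, beyond the scatter of two such steps

On the core of compound 2, the methyl that sits meta to a fused ring and para to a fused ring counts for much, with a 160-fold higher number from compound 2 to compound 4 (2.20 log units; beyond the scatter), and a second change, hydrogen in place of methyl on a saturated chain carbon bound to an oxygen next to a carbonyl group, gave a 5.4-fold lower number from compound 1 to compound 4 (0.73 log units; beyond the scatter). What this does not show is whether the gap between the two steps comes from the different place of the aromatic methyl or from the different chain on the two cores, and two steps give no rule for any further core.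

Open, as far as these compounds go, is whether a chlorine atom or a methoxy group in the place of that aromatic methyl would keep the low number of compound 2. Also open, from the compounds shown here alone, is how a longer chain, such as propyl, would fare on the oxygen next to the carbonyl group when that aromatic methyl is present.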